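Swapping chloro for hydroxy on the benzyl group

This account rests on a few compounds, and the source may have more. Where it says the series, first, only, none or still open, it means among the compounds named here.

Compound 3 `NC(=O)Cc1cc(=O)oc2cc(OCc3cccc(Cl)c3)ccc12` stands at the top of the two numbers measured in an assay (strain Wistar) for inhibition of Amine oxidase [flavin-containing] A (Rattus norvegicus) (a lower number here means a stronger inhibitor, a higher number a weaker inhibitor), where compound 3 gives 26000 nM. Compound 2 `NNC(=O)Cc1cc(=O)oc2cc(OCc3cccc(Cl)c3)ccc12` gives 2500 nM, and the step of a 10-fold higher number from compound 2 to compound 3 (1.02 log units; beyond the scatter) is the only fully resolved one. Compound 1 `NC(=O)[C@H](CO)Nc1cc(=O)oc2cc(OCc3cccc(Cl)c3)ccc12` reaches only the limit > 100000 nM in this assay. Starting from that limit, an at least 40-fold lower number from compound 1 to compound 2 (1.60 log units; beyond the scatter) and an at least 3.8-fold lower number from compound 1 to compound 3 (0.58 log units; beyond the scatter) are lower bounds. Compound 4 `NC(=O)Cc1cc(=O)oc2cc(OCc3cccc(O)c3)ccc12` differs from compound 3 by hydroxy in place of chloro on an aromatic carbon. Going by the values given here, none of the measured steps touches this part of the molecule; all of them alter the side chain on the shared core, so they offer no guide for the benzyl substituent. The chemist therefore expects a modest weakening, a 2.3-fold higher number from compound 3 to compound 4 (0.36 log units; beyond the scatter), with wide uncertainty. His estimate for compound 4 is 60000 nM, between 15000 nM and 250000 nM.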

Compound 4, half-maximal inhibitory concentration: 4270 nM
The estimate for compound 4 lay 14-fold (1.15 log units) above the measured number, outside the stated range (below it).
By their numbers in this assay, from the lowest: compounds 2 and 4 (each within the scatter of the next); then compound 3. At a limit, above all of these: compound 1.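

The earlier compounds shown here changed only the side chain on the shared core, whereas this change shows that the substituent on the benzyl group also moves the number in this assay, with hydroxy in place of chloro giving a 6.1-fold lower number from compound 3 to compound 4 (0.78 log units; beyond the scatter). With the carbamoylmethyl side chain, 3-hydroxybenzyl therefore gives the lower number of the two. Nothing in the data shown accounts for this step.

From the compounds shown here alone, whether the swap has the same effect alongside the side chain of compound 2 remains open, as does how a methoxy group or an amine would compare at this place.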